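Replacing a diethylamino with butyl on the shared core

A few compounds are considered here, and "the series" means these few. Any claim that something is new, unique, unknown or untested is made for them only; others in the source may bear on it.

Of the compounds shown here, two built on the same core have been measured in a functional assay on HT-29 cells (Homo sapiens) for antiproliferative activity, read by MTT assay, with a stated time of 96 h; a higher number here means a weaker inhibitor, a lower number a stronger inhibitor. Compound 1 `CCN(CC)c1ccc(N2C(=O)NC3(CSC4=C3C(=O)c3ncccc3C4=O)C2=O)cc1` carries a diethylamino group on a six-membered aromatic ring of carbon only, and in this assay compound 1 gives 50 nM. Compound 2 `O=C1NN(c2ccc(Cl)cc2)C(=O)C2(CSC3=C2C(=O)c2ncccc2C3=O)N1` differs in several places at once, and in this assay compound 2 gives 220 nM. Of the two numbers, that of compound 1 is the lower one, and the gap to compound 2 lies beyond the usual scatter of repeated measurements, so compound 1 stands as the stronger inhibitor of the pair.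

Compound 3 `CCCCc1ccc(N2C(=O)NC3(CSC4=C3C(=O)c3ncccc3C4=O)C2=O)cc1` has not yet been measured. It differs from compound 1 in a single place: butyl in place of diethylamino on an aromatic carbon. For the measured compounds named here, no pair of measured compounds shows this change in isolation, so its effect on the numbers is unknown here.

Given that, the step expected from compound 1 to compound 3 in this assay is a small one, a 2.2-fold higher number from compound 1 to compound 3 (0.34 log units; beyond the scatter), toward a somewhat higher number, though it may well fall within the scatter. Compound 3 is therefore estimated to give 110 nM, within a range from 40 nM to 320 nM.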

Compound 3, half-maximal inhibitory concentration: 50 nM
Compound 3: the middle estimate sits 2.2-fold (0.34 log units) above what was measured; low and high end bracket the measured number.
By their numbers in this assay, from the lowest: compounds 1 and 3 (each within the scatter of the next); then compound 2.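

For the compounds shown here, exchanging diethylamino for butyl on an aromatic carbon of the six-membered aromatic ring, para to a large group, gives in this assay a step of no change at the digits printed from compound 1 to compound 3 (within the scatter), the first step at this position that can be read in isolation. The nitrogen of the diethylamino group and its one hydrogen-bond acceptor can thus be absent from this place without the number moving beyond the scatter, since butyl, made of carbon only, reads alike on the shared core. No measurement given here bears on why these two different groups read alike.

The compounds shown leave open how far this tolerance extends, since only two groups have been compared at this place, and a carboxylic acid, a primary amine, a methyl group or a longer chain such as octyl could read quite differently there. They also leave open whether the same exchange would read alike on the differently built core of compound 2, or in cells other than those of this one assay.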